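Aryl variation on the shared core: compound 4

A few compounds are considered here, and "the series" means these few. Any claim that something is new, unique, unknown or untested is made for them only; others in the source may bear on it.

Measured so far:
compound 1, `CC#CC(CC(=O)O)c1ccc(OCc2ccc3nc(-c4ccc(F)cc4F)cn3c2)cc1`, 825 nM
compound 2, `CC#CC(CC(=O)O)c1ccc(OCc2ccc3nc(-c4ccc(C5CCCCC5)cc4)cn3c2)cc1`, 417 nM
compound 3, `CC#CC(CC(=O)O)c1ccc(OCc2ccc3nc(-c4ccc(C)cc4C)cn3c2)cc1`, 316 nM

In an assay on isolated protein for agonist activity at Free fatty acid receptor 1 (Homo sapiens) (on this read-out lower numbers stand for an effect already at smaller amounts and higher numbers for an effect only at larger amounts of compound), compound 3 shows the lowest of the three numbers. Compound 2 sits within the scatter of compound 3, a 1.3-fold lower number from compound 2 to compound 3 (0.12 log units; within the scatter), whereas compound 1 stands beyond it, a 2.6-fold lower number from compound 1 to compound 3 (0.42 log units; beyond the scatter). Compound 4, `CC#CC(CC(=O)O)c1ccc(OCc2ccc3nc(-c4ccccc4F)cn3c2)cc1`, differs from compound 3 in one place: 2-fluorophenyl in place of 2,4-dimethylphenyl on an aromatic carbon. The step that bears on this change is a 2.6-fold lower number from compound 1 to compound 3 (0.42 log units; beyond the scatter), which exchanged a fluorinated phenyl for a methylated one; a 2.0-fold lower number from compound 1 to compound 2 (0.30 log units; within the scatter) lay within the scatter. Since compound 4 carries a fluorinated phenyl again, a number between compound 3 and compound 1 is expected, that is a 1.9-fold higher number from compound 3 to compound 4 (0.28 log units; within the scatter). Compound 4 is estimated at 600 nM, with a range from 250 nM to 1500 nM.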

Compound 4, half-maximal effective concentration: 583 nM
Compound 4: middle estimate off by 1.0-fold (0.01 log units), on the high side; low and high end bracket the measured number.
By their numbers in this assay, from the lowest: compounds 3, 2, 4 and 1 (each within the scatter of the next, the first and the last beyond it).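

In this assay, 2-fluorophenyl at this position cannot be distinguished from 2,4-dimethylphenyl (a 1.8-fold higher number from compound 3 to compound 4 (0.27 log units; within the scatter)) or from 4-cyclohexylphenyl (a 1.4-fold higher number from compound 2 to compound 4 (0.15 log units; within the scatter)). Hydrogen in place of the second fluoro also gives no readable change (a 1.4-fold lower number from compound 1 to compound 4 (0.15 log units; within the scatter)), so compound 4 lies within the scatter of both compound 1 and compound 3, although those two stand apart beyond it. No supporting data explain these results. Open, going by these compounds, is whether a methyl in place of the fluoro of compound 4 would give a number beyond the scatter of compound 4. On these data alone, a methoxy or nitrile there remains equally open.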